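Cytotoxicity when the amide side chain grows a short linker

The compounds below may be only part of what the source reports. "The series", "measured", "known", "first", "only" and "open" are said of these compounds alone.

Measured compounds:
Compound 1 `C#CCNC(=O)/C=C/c1cnc(Nc2ccc(C#N)cc2)nc1Oc1c(C)cc(C#N)cc1C`: > 222 nM
Compound 2 `Cc1cc(C#N)cc(C)c1Oc1nc(Nc2ccc(C#N)cc2)ncc1/C=C/C(=O)NC1CCN(S(C)(=O)=O)CC1`: > 175 nM

Two compounds share a core and differ only in the group on an amide-type nitrogen. In an ADME assay on TZM cells (Homo sapiens) for cytotoxicity, with a stated time of 1 days (on this read-out lower numbers stand for higher toxicity in this test and higher numbers for lower toxicity in this test), compound 1 gives > 222 nM, which is a limit of the assay rather than a number. Compound 2 gives > 175 nM in this assay, again only a limit. The step that the two limits leave unreadable from compound 1 to compound 2 therefore cannot be read, since both values sit at limits the limit of > 175 nM in this assay, at which 1 of the 2 values shown sits (the limit of > 222 nM in this assay, at which 1 of the 2 values shown sits). Compound 3 `Cc1cc(C#N)cc(C)c1Oc1nc(Nc2ccc(C#N)cc2)ncc1/C=C/C(=O)NCCN1CCN(S(C)(=O)=O)CC1` carries the change (2-(4-(methylsulfonyl)piperazin-1-yl)ethyl in place of 1-(methylsulfonyl)piperidin-4-yl on an amide-type nitrogen), so that a 2-(4-(methylsulfonyl)piperazin-1-yl)ethyl group replaces the 1-(methylsulfonyl)piperidin-4-yl group on the amide-type nitrogen. Within the data shown here, the only measured step gives no readable size, so no direction can be inferred, and compound 3 is expected to behave like the measured pair. The expected step is a step that the limit leaves unreadable from compound 2 to compound 3. For compound 3 a half-maximal cytotoxic concentration of 300 nM is estimated, within 150 nM to 1200 nM, most likely reported again as a limit.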

Compound 3, half-maximal cytotoxic concentration: > 166 nM
Compound 3: only a limit was reported; the forecaster's own chance of this, stated with the estimate: 70%; the middle value does not contradict the limit.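

In this assay compound 3 gives > 166 nM, which is again only a limit of the assay. Its steps to compound 1 and compound 2 therefore cannot be read. The compounds shown leave open whether the group on the amide-type nitrogen changes the half-maximal cytotoxic concentration at all.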